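A Ring Exchange on Compound 2

The source may report more compounds than this note shows. Statements on the series, on what has been measured and on what is new or still open speak of the compounds shown alone.

Compound 1 `CCNC(=O)Nc1ccc(-c2nc(C(C)(C)S(C)(=O)=O)cc([C@@]34CCOC[C@@H]3C4)n2)cc1`: 4.7
Compound 2 `CCNC(=O)Nc1ccc(-c2nccc([C@@]34CCOC[C@@H]3C4)n2)cc1`: 3.9

Going by the values given here, in a physicochemical assay for lipophilicity (on this read-out higher numbers stand for higher lipophilicity and lower numbers for lower lipophilicity), compound 2 stands at 3.9, the lower of the two numbers so far, and the only neighbour is compound 1 at 4.7. Compound 3 `CCNC(=O)Nc1ccc(-c2nccc(C3=CCOCC3)n2)cc1` differs from compound 2 in one group on an aromatic carbon: a group of 6 heavy atoms (5 carbon, 1 oxygen; one six-membered non-aromatic ring with 1 hetero atom) in place of a group of 7 heavy atoms (6 carbon, 1 oxygen; one three-membered non-aromatic ring of carbon only, one six-membered non-aromatic ring with 1 hetero atom), on an aromatic carbon. Among the compounds with values here, no measured step covers this exchange. The only one, a number 0.80 log units lower from compound 1 to compound 2 (beyond the scatter), is modest and beyond the scatter, and it replaces 1-methyl-1-(methylsulfonyl)ethyl with hydrogen, so it bears on this change only loosely. There too, the compound with fewer atoms gave the lower number. A small step is therefore expected, a number 0.20 log units lower from compound 2 to compound 3 (within the scatter), an estimated fall that stays within the scatter. The expectation starts from compound 2 at 3.9. For compound 3 the estimated value is 3.7, with an expected range from 3.2 to 4.1.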

Compound 3, partition coefficient: 3.6
Compound 3: middle estimate off by 0.10 log units, on the high side; the range from low to high includes it.
By their numbers in this assay, from the lowest: compounds 3 and 2 (each within the scatter of the next); then compound 1.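

Going by these compounds alone, compound 1 and compound 2 differ in another place, so this is the first reading of a change to the group on the aromatic carbon next to the ring nitrogen. In this assay, a six-membered non-aromatic ring with a double bond outside aromatic rings replaces the group that also holds a three-membered ring and the defined stereocentres, giving a number 0.30 log units lower from compound 2 to compound 3 (within the scatter), so the two compounds cannot be told apart on this read-out. Nothing measured on these compounds offers an explanation for this result.

Going by these compounds, it remains open how a quite different group in this place, such as an amine like morpholine or a carboxylic acid, would read in this assay. Also open, on these data alone, is whether the same exchange would give a similar step with 1-methyl-1-(methylsulfonyl)ethyl present on the core.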